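Stereoisomers in a cytotoxicity read-out: from compound 2 to compound 3

This account rests on a few compounds, and the source may have more. Where it says the series, first, only, none or still open, it means among the compounds named here.

Measured in an ADME assay on Akata cells (Homo sapiens) for cytotoxicity; a higher number here means that more compound is tolerated, a lower number that less compound is tolerated:
- Compound 1 `Nc1nc2c(ncn2/C=C2/C[C@@H]2[C@@H](O)CO)c(=O)[nH]1`: 56000 nM
- Compound 2 `Nc1nc2c(ncn2/C=C2/C[C@H]2[C@@H](O)CO)c(=O)[nH]1`: 78000 nM

In this assay compound 2 gives 78000 nM, which lies within the scatter of compound 1, so the two cannot be ranked. Compound 3 `Nc1nc2c(ncn2/C=C2\C[C@H]2[C@H](O)CO)c(=O)[nH]1` has not yet been measured. Its relation to compound 2 is this: the two compounds have the same atoms and bonds and differ only in configuration as drawn: 2 of 3 stereo elements differ; a stereocentre at a saturated chain carbon is drawn R in compound 2 and S in compound 3; a double bond is drawn Z in compound 2 and E in compound 3. For the measured compounds named here, the one measured step, a 1.4-fold higher number from compound 1 to compound 2 (0.14 log units; within the scatter), also changes configuration alone, but at a saturated ring carbon, so it bears on the new change only indirectly. On that single small step, no shift beyond the scatter is expected, and the estimated step is a 1.1-fold lower number from compound 2 to compound 3 (0.05 log units; within the scatter). Compound 3 is expected at about 70000 nM, with an estimated range from 32000 nM to 150000 nM.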

Compound 3, half-maximal cytotoxic concentration: 86600 nM
Compound 3: the middle estimate sits 1.2-fold (0.09 log units) below what was measured; measured number inside the range.
By their numbers in this assay, from the lowest: compounds 1, 2 and 3 (each within the scatter of the next).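

In this assay, the double bond and the saturated chain carbon now change together, and this gives a 1.1-fold higher number from compound 2 to compound 3 (0.05 log units; within the scatter). Changing every stereo element at once gives a 1.5-fold higher number from compound 1 to compound 3 (0.19 log units; within the scatter), so no configuration shown here separates these compounds in this assay, even when all the stereo elements differ. The comparison speaks to configuration alone: the fact that compounds 1 and 3 differ only in the configuration as drawn.

The double bond and the chain carbon change together in compound 3, so the data cannot show what each does alone, or whether two separate effects offset each other. As far as these compounds go, all three compounds carry the same atoms and bonds, so it stays open how an amine or a carboxylic acid in place of a chain hydroxyl would read in this assay.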